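The source may hold more compounds than are shown below. What is called first, only, known or untested is meant among the compounds shown, and "the series" means these compounds.

Measured compounds in a functional assay on HeLa cells for agonist activity at 5-hydroxytryptamine receptor 6 (Homo sapiens), read by immunoassay; on this read-out lower numbers stand for smaller maximal responses and higher numbers for larger maximal responses: compound 1 `NCCn1cc(S(=O)(=O)c2ccccc2)c2ccccc21` gives 67%; compound 2 `CN(C)CCn1cc(S(=O)(=O)c2cc(Cl)cc(Cl)c2)c2cccnc21` gives 80%; compound 3 `NCCn1cc(S(=O)(=O)c2cc(Cl)cc(Cl)c2)c2cccnc21` gives 65%.

Compound 2 stands highest of these three in this assay, with compound 1 its nearest neighbour and compound 3 the furthest away. Within the data shown here, the only single-point step measured, a number 15 percentage points lower from compound 2 to compound 3 (beyond the scatter), concerns the amine on the chain and not the aryl group on the sulfonyl sulfur. Compound 4 `CN(C)CCn1cc(S(=O)(=O)c2cccs2)c2cccnc21` alters that aryl group instead: thiophen-2-yl in place of 3,5-dichlorophenyl on a sulfonyl sulfur. Among the measured compounds shown here, no measured step bears on this change, and the values of compounds 1 and 3 lie within the scatter of each other. The expected step is therefore a number 8 percentage points lower from compound 2 to compound 4 (within the scatter), a modest drift rather than a change beyond the scatter. Compound 4 is estimated at 72%, with a range from 55% to 90%.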

Compound 4, largest response reached (Emax), in percent of the reference or control that the assay uses: 74%
Compound 4: middle estimate off by 2 percentage points, on the low side; measured number inside the range.
By their numbers in this assay, from the lowest: compounds 3, 1, 4 and 2 (each within the scatter of the next, the first and the last beyond it).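

In this assay, among these compounds, the exchange on the sulfonyl sulfur gives a number 6 percentage points lower from compound 2 to compound 4 (within the scatter) and so provides the first direct reading at this position. For this pair, thiophen-2-yl in place of 3,5-dichlorophenyl leaves the maximal response within the scatter, and neither the six-membered aromatic ring nor the two chlorine atoms are required for compound 4 to reach 74% in this assay. No available evidence accounts for this similarity. On these data alone, it remains open whether furan-2-yl or unsubstituted phenyl on the same sulfur would read alike. Also open, as far as these compounds go, is whether an amino group in place of dimethylamino on the chain of compound 4 would produce a drop like a number 15 percentage points lower from compound 2 to compound 3 (beyond the scatter) in this setting.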